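A Methyl on the Hydroxyamino Group: Compound 3 to Compound 4

The compounds below may be only part of what the source reports. "The series", "measured", "known", "first", "only" and "open" are said of these compounds alone.

Three compounds have been measured in an ADME assay on MT4 cells (Homo sapiens) for cytotoxicity, read by spectrophotometry, with a stated time of 5 days; a higher number here means that more compound is tolerated, a lower number that less compound is tolerated:

compound 1 `CONC(=S)N/N=C1\C(=O)N(CN(C)C)c2ccc(C)cc21`: 622000 nM
compound 2 `Cc1ccc2c(c1)/C(=N/NC(=S)NO)C(=O)N2CN1CCN(c2ccccc2)CC1`: 420000 nM
compound 3 `CCn1cc(C(=O)O)c(=O)c2cc(F)c(N3CCN(CN4C(=O)/C(=N\NC(=S)NO)c5cc(C)ccc54)C(C)C3)c(F)c21`: 244000 nM

Among these three, compound 3 gives the lowest number in this assay. Its gap to compound 2 lies within the usual scatter of repeated measurements, so the two cannot be told apart on these numbers. Its gap to compound 1 lies beyond the scatter, and compound 1 shows the higher number of the two.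

Compound 4 `CCn1cc(C(=O)O)c(=O)c2cc(F)c(N3CCN(CN4C(=O)/C(=N\NC(=S)NOC)c5cc(C)ccc54)C(C)C3)c(F)c21` has not yet been measured. It differs from compound 3 in one place: methyl in place of hydrogen on an oxygen. Put another way, a hydroxy becomes a methoxy, so the hydroxyamino group becomes a methoxyamino group. Among the measured compounds shown here, no measured pair in this set shows what such a change does, so there is nothing here to lean on beyond the small size of the change as counted. A small step in this assay is expected, not beyond the scatter, in either direction. Compound 4 is estimated to give about 244000 nM, with a range from 120000 nM to 500000 nM. The step of no change at the digits printed from compound 3 to compound 4 (within the scatter) implied by this estimate is expected to stay within the scatter.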

Compound 4, half-maximal cytotoxic concentration: 156000 nM
The estimate for compound 4 lay 1.6-fold (0.19 log units) above the measured number; the range from low to high includes it.
By their numbers in this assay, from the lowest: compounds 4, 3, 2 and 1 (each within the scatter of the next, the first and the last beyond it).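

In this assay, replacing the hydrogen on the oxygen with methyl, which turns the hydroxyamino group into a methoxyamino group, gives a 1.6-fold lower number from compound 3 to compound 4 (0.19 log units; within the scatter). Among the compounds shown here, this is the first pair in the set that differs in one place, and it shows that at this position the added methyl does not produce a difference that can be separated from the ordinary spread of repeated measurements, so here the hydroxy hydrogen is not needed to keep the number within that spread. Nothing measured in this set bears on why the number behaves this way.

One pair at one position cannot show whether larger groups on this oxygen, such as an ethyl group, a longer chain or an acetyl group, would also stay within the scatter. It also leaves open whether the same methyl step would read alike on a different core, such as that of compound 2, whose hydroxyamino group has no methoxyamino partner among the compounds shown here.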